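The source may hold more compounds than are shown below. What is called first, only, known or untested is meant among the compounds shown, and "the series" means these compounds.

In a functional assay on FM3A cells (Mus musculus) for antiproliferative activity, read by cell counting, with a stated time of 2 days (a higher number here means a weaker inhibitor, a lower number a stronger inhibitor), compound 1 `COc1ccc(Nc2nc(N)c(C(=O)c3ccccc3)s2)cc1` gives 730 nM. Compound 2 `COc1ccc(Nc2nc(N)c(C(=O)c3ccc(Cl)cc3)s2)cc1`, with chloro in place of hydrogen on an aromatic carbon, gives 59 nM, and compound 3 `COc1ccc(Nc2nc(N)c(C(=O)c3ccc(Br)cc3)s2)cc1`, with bromo at that same carbon, gives 100 nM. Compound 3 therefore stands within the scatter of compound 2 and well under compound 1 on this scale. Both halogens lowered the number clearly, with a 12-fold lower number from compound 1 to compound 2 (1.09 log units; beyond the scatter) for chloro and a 7.3-fold lower number from compound 1 to compound 3 (0.86 log units; beyond the scatter) for bromo. Exchanging one halogen for the other, a 1.7-fold higher number from compound 2 to compound 3 (0.23 log units; within the scatter), made no difference beyond the scatter.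

Compound 4 `COc1ccc(Nc2nc(N)c(C(=O)c3ccc([N+](=O)[O-])cc3)s2)cc1` has nitro in place of bromo on an aromatic carbon, para to a large group: nitro in place of bromo on an aromatic carbon. Among the compounds with values here, no tested compound carries a nitro group, so the evidence is indirect. The steps from compound 1 show that the number responds strongly to a change at this carbon, so a nitro group could move it either way. The close values of compound 2 and compound 3 offer no guide beyond the two halogens. A small rise in the number is expected, with wide uncertainty. The estimated step is a 1.6-fold higher number from compound 3 to compound 4 (0.20 log units; within the scatter). For compound 4 the estimate is 160 nM, with an expected range from 40 nM to 600 nM.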

Compound 4, half-maximal inhibitory concentration: 310 nM
Compound 4: middle estimate off by 1.9-fold (0.29 log units), on the low side; the measured number falls inside the stated range.
By their numbers in this assay, from the lowest: compounds 2 and 3 (each within the scatter of the next); then compound 4; then compound 1.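

Replacing hydrogen on this aromatic carbon, para to a large group, does not lower the number by one fixed amount in this assay: nitro in place of hydrogen gives a 2.4-fold lower number from compound 1 to compound 4 (0.37 log units; beyond the scatter) and remains a clear gain, but a smaller one than either halogen gave. Set directly against the halogens, nitro gives a 3.1-fold higher number from compound 3 to compound 4 (0.49 log units; beyond the scatter) and a 5.3-fold higher number from compound 2 to compound 4 (0.72 log units; beyond the scatter) even though the exchange of chloro and bromo stayed within the scatter, so this carbon separates one substituent from another and not merely substituent from hydrogen. Nothing available accounts for the separation of the nitro group, with its three heavy atoms and two hydrogen-bond acceptors, from the two halogens.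

The compounds shown carry only hydrogen, chloro, bromo and nitro at this carbon, so they leave open where an amine, a methyl group or a carboxylic acid would fall on this scale. They also leave open whether the gap between nitro and the halogens would persist with these groups on another carbon of the same ring.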